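The source may report more compounds than this note shows. Statements on the series, on what has been measured and on what is new or still open speak of the compounds shown alone.

In a functional assay on K562 cells (Homo sapiens) for antiproliferative activity, read by MTT assay, with a stated time of 24 h (on this read-out higher numbers stand for weaker inhibition and lower numbers for stronger inhibition), compound 2 `COc1ccc(C(=O)/C=C/c2ccc(F)cc2)c2c1C=CC(C)(C)O2` gives only a limit, > 10000 nM. Compound 1 `COc1ccc(C(=O)/C=C/c2cc(OC)c(OC)c(OC)c2)c2c1C=CC(C)(C)O2` likewise gives only a limit in this assay, > 10000 nM. Among the compounds with values here, compound 3 `COc1ccc(C(=O)/C=C/c2ccc3ccccc3n2)c2c1C=CC(C)(C)O2` is the single member of the set with a number in this assay, 3020 nM. Within the data shown here, compound 2 thus sits at the limit of > 10000 nM in this assay, at which 2 of the 3 values shown sit, and no step between measured compounds that differ in one place is available from it. Compound 4 `COc1ccc(C(=O)/C=C/c2ccsc2)c2c1C=CC(C)(C)O2` has not yet been measured in this assay. It differs from compound 2 by thiophen-3-yl in place of 4-fluorophenyl on a double-bonded chain carbon bound to a double-bonded chain carbon; in words, thiophen-3-yl in place of 4-fluorophenyl on a double-bonded chain carbon bound to a double-bonded chain carbon. Among the measured compounds shown here, no measured step exists to show how such a change bears on the read-out. The step from compound 2 to compound 4 is expected to be a step that the limit leaves unreadable from compound 2 to compound 4, that is, no change beyond the scatter, with compound 4 most likely again reported only as a limit. For compound 4 the estimate in this assay is 12000 nM, within a range from 4000 nM to 40000 nM.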

Compound 4, half-maximal inhibitory concentration: > 10000 nM
Compound 4 ended at the assay's limit; the forecaster's own chance of this, stated with the estimate: 70%; the middle value is on the limit's open side.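

Within the data shown here, compound 2 and compound 4 each give only a limit in this assay, and no step between them can be read. The compounds shown leave open how thiophen-3-yl in place of 4-fluorophenyl bears on the read-out, since neither compound has a number.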